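A few compounds are considered here, and "the series" means these few. Any claim that something is new, unique, unknown or untested is made for them only; others in the source may bear on it.

Compound 1 `O=C(OC1CCC(CN2CCN(c3cc(=O)c4cc(C(F)(F)F)cc([N+](=O)[O-])c4s3)CC2)CC1)c1ccccc1` with 68.1% 
Compound 2 `NC1CCC(CN2CCN(c3cc(=O)c4cc(C(F)(F)F)cc([N+](=O)[O-])c4s3)CC2)CC1` with 107% 

Among the compounds with values here, in an ADME assay on cells (Hepatocyte, Mus musculus) for metabolic stability, with a stated time of 30 min (on this read-out lower numbers stand for a less stable compound and higher numbers for a more stable compound), compound 2 gives 107% and stands highest of the two compounds measured so far. Compound 3 `CS(=O)(=O)NC1CCC(CN2CCN(c3cc(=O)c4cc(C(F)(F)F)cc([N+](=O)[O-])c4s3)CC2)CC1` has not yet been measured. It differs from compound 2 by methylsulfonyl in place of hydrogen on an amine nitrogen and so carries methylsulfonyl in place of hydrogen on an amine nitrogen. Within the data shown here, one measured step bears on this: a number 38.9 percentage points higher from compound 1 to compound 2 (beyond the scatter) is large, with amino in place of benzoyloxy on a saturated ring carbon. Among the measured compounds shown here, no measured compound carries methylsulfonyl, so this is weak guidance. For the measured compounds named here, the only compound without the free amino, compound 1 at 68.1% in this measurement, lies lower, so a moderate fall is expected, smaller than that step. The expected change is a number 19 percentage points lower from compound 2 to compound 3 (beyond the scatter) in this assay by this estimate. For compound 3 the estimate is 88% with an expected range from 65% to 108% as its bounds.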

Compound 3, percent of the compound remaining: 111%
Compound 3: the middle estimate sits 23 percentage points below what was measured; measured number outside the range, above it.
By their numbers in this assay, from the lowest: compound 1; then compounds 2 and 3 (each within the scatter of the next).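

In this assay methylsulfonyl in place of hydrogen on the amine nitrogen gives a number 4 percentage points higher from compound 2 to compound 3 (within the scatter) and so leaves compound 2 and compound 3 indistinguishable, which shows that the free amino is not needed to keep the number this high. Replacing benzoyloxy on the saturated ring carbon with methanesulfonamido gives a number 42.9 percentage points higher from compound 1 to compound 3 (beyond the scatter) and this large step matches the earlier one with amino, leaving compound 1 alone at the low end of the three. Nothing measured here explains why the nitrogen tolerates this change.

Going by these compounds, it remains open whether acetyl or phenylsulfonyl on the same nitrogen would behave like methylsulfonyl. On these data alone, it is equally open where a hydroxyl or a carboxylic acid on the saturated ring carbon would fall relative to amino and benzoyloxy.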